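A few compounds are considered here, and "the series" means these few. Any claim that something is new, unique, unknown or untested is made for them only; others in the source may bear on it.

Compound 1 `COc1ccc([S+]([O-])c2cccc(N)c2C#N)cc1`: > 200000 nM (a limit, not a number)
Compound 2 `CCCOc1cc(C)cc(S(=O)(=O)c2cccc(N)c2C#N)c1`: 11000 nM
Compound 3 `N#Cc1c(N)cccc1S(=O)(=O)c1cccc(Br)c1`: > 200000 nM (a limit, not a number)

Going by the values given here, in a functional assay on MT4 cells (Homo sapiens) for cytotoxicity (a lower number here means a stronger inhibitor, a higher number a weaker inhibitor), compound 2 gives 11000 nM, the only true number in this small set. The rest of the picture is the limit of > 200000 nM in this assay, at which 2 of the 3 values shown sit.

Compound 4 `COc1cc(C)cc(S(=O)(=O)c2cccc(N)c2C#N)c1` is still unmeasured. It departs from compound 2 by one change: hydrogen in place of ethyl on a saturated chain carbon bound to an oxygen on an aromatic ring, turning propoxy into methoxy. Among the compounds with values here, no measured pair shows this change directly, so a moderate move towards a higher number, meaning a weaker effect, is only a cautious expectation. The estimated move is a 3.6-fold higher number from compound 2 to compound 4 (0.56 log units; beyond the scatter). Compound 4 is expected near 40000 nM, with an estimated range of 10000 nM to 200000 nM.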

Compound 4, half-maximal inhibitory concentration: 94000 nM
Beside the measured number, compound 4's estimate is 2.4-fold (0.37 log units) below it, within the range that was stated.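

Going by these compounds alone, this is the first single change in the set that can be read: in this assay, going from propoxy to methoxy gives an 8.5-fold higher number from compound 2 to compound 4 (0.93 log units; beyond the scatter). The length of the chain on this oxygen therefore moves the number, and the shorter methoxy gives the weaker effect, though this rests on one pair. Compound 1 and compound 3 remain limits, not numbers: the limit of > 200000 nM in this assay, at which 2 of the 4 values shown sit.

As far as these compounds go, whether a longer chain such as butoxy would lower the number further remains open. So does the effect of a branched isopropoxy or an amine at the end of the chain.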